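The source may report more compounds than this note shows. Statements on the series, on what has been measured and on what is new or still open speak of the compounds shown alone.

Compound 1 `COc1cc2c(cc1OC)CN(S(=O)(=O)c1ccc(-n3cc(COc4ccc([N+](=O)[O-])cc4)nn3)cc1)CC2` in an assay on isolated protein for inhibition of Aromatase (Homo sapiens), read by fluorescence, with a stated time of 10 min, tested at 12.5 uM (on this read-out higher numbers stand for more inhibition at the one concentration tested (going by the name of the read-out) and lower numbers for less inhibition), gives 14%. Compound 2 `O=c1cc(OCc2cn(-c3ccc(S(=O)(=O)N4CCc5ccccc5C4)cc3)nn2)c2ccccc2o1` in this assay gives 14%, so compound 1 stands level with compound 2 at the digits shown, the two values falling within the scatter of each other. Compound 3 `COc1cc2c(cc1OC)CN(S(=O)(=O)c1ccc(-n3cc(COc4cc(C=O)ccc4OC)nn3)cc1)CC2` differs from compound 1 by 5-formyl-2-methoxyphenyl in place of 4-nitrophenyl on an oxygen on a saturated carbon. Going by the values given here, no measured pair carries a comparable change, so the size of this step rests only on the weak level of compound 1 at 14%. The step is expected to be a number 1 percentage points higher from compound 1 to compound 3 (within the scatter), no larger than the scatter in either direction. For compound 3 the estimate in this assay is 15%, with a range from 4% to 30%.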

Compound 3, a percentage reported as inhibition, at one concentration (the size of the read-out at that concentration, not a potency): 14%
Compound 3: middle estimate off by 1 percentage points, on the high side; measured number inside the range.
By their numbers in this assay, from the lowest: compounds 1, 2 and 3 (each within the scatter of the next).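

In this assay, 5-formyl-2-methoxyphenyl in place of 4-nitrophenyl on an oxygen on a saturated carbon gives no change at the digits printed from compound 1 to compound 3 (within the scatter) and so leaves the read-out unmoved. This position therefore accepts a swap of one substituted phenyl for another without any change beyond the scatter, and compound 3 stays at the weak level of 14% in this assay. Nothing available explains this lack of change. As far as these compounds go, whether any group on this oxygen can raise inhibition remains open. A carboxylic acid or an amine on the phenyl ring, or a longer chain in its place, would test this.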